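A few compounds are considered here, and "the series" means these few. Any claim that something is new, unique, unknown or untested is made for them only; others in the source may bear on it.

Measured so far in a functional assay on HCT-116 cells (Homo sapiens) for inhibition, read by colorimetric assay, with a stated time of 3 days; a lower number here means a stronger inhibitor, a higher number a weaker inhibitor
compound 1 `O=C(CCCCCCNC(=O)C(O)(O)C(F)(F)F)Nc1ccncc1` 6670 nM
compound 2 `O=C(CCCCCCNC(=O)C(O)(O)C(F)(F)F)Nc1ccc(F)cc1F` 18500 nM

Compound 2 stands highest of the two at 18500 nM and is the weaker inhibitor. The change to compound 3 `O=C(CCCCCCNC(=O)C(O)(O)C(F)(F)F)Nc1ccc(Br)cc1` is 4-bromophenyl in place of 2,4-difluorophenyl on an amide-type nitrogen and places 4-bromophenyl on the amide-type nitrogen in place of 2,4-difluorophenyl. Going by the values given here, one measured step bears on it, at the same place: a 2.8-fold higher number from compound 1 to compound 2 (0.44 log units; beyond the scatter), modest but beyond the scatter. Among the compounds with values here, no measured compound carries bromine, so a smaller step towards a lower number is expected, probably within the scatter. The expected step is a 1.5-fold lower number from compound 2 to compound 3 (0.19 log units; within the scatter) in this assay. For compound 3 the estimate is 12000 nM, with an expected range from 5000 nM to 28000 nM.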

Compound 3, half-maximal inhibitory concentration: 3130 nM
Beside the measured number, compound 3's estimate is 3.8-fold (0.58 log units) above it; measured number outside the range, below it.
By their numbers in this assay, from the lowest: compound 3; then compound 1; then compound 2.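

In this assay, the aryl group on the amide-type nitrogen moves the number in both directions: 4-bromophenyl in place of 2,4-difluorophenyl gives a 5.9-fold lower number from compound 2 to compound 3 (0.77 log units; beyond the scatter) and 4-bromophenyl in place of pyridin-4-yl gives a 2.1-fold lower number from compound 1 to compound 3 (0.33 log units; beyond the scatter) within this set. A carbon-only aromatic ring therefore does not by itself give a higher number than pyridin-4-yl, since compound 2 and compound 3 fall on opposite sides of compound 1. No evidence on hand explains this shift.
The step from compound 2 to compound 3 swaps both the halogen and the substitution pattern, so their contributions remain unseparated. 4-Chlorophenyl and unsubstituted phenyl would help separate them.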